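From Bromo to Hydroxy: Expecting a Weaker Inhibitor

A few compounds are considered here, and "the series" means these few. Any claim that something is new, unique, unknown or untested is made for them only; others in the source may bear on it.

In an assay for inhibition of Dihydrofolate reductase (Gallus gallus) (on this read-out higher numbers stand for weaker inhibition and lower numbers for stronger inhibition), compound 2 `Nc1ncc(Cc2ccccc2Br)c(N)n1` gives 12300 nM. Compound 1 `CCCCOc1ccccc1Cc1cnc(N)nc1N` gives 8710 nM, and compound 3 `COc1ccccc1Cc1cnc(N)nc1N` gives 28800 nM, so compound 2 stands second highest of the three numbers, with a 1.4-fold higher number from compound 1 to compound 2 (0.15 log units; within the scatter) and a 2.3-fold higher number from compound 2 to compound 3 (0.37 log units; beyond the scatter). Compound 4 `Nc1ncc(Cc2ccccc2O)c(N)n1` differs from compound 2 by hydroxy in place of bromo on an aromatic carbon. Two measured steps bear on this change: the step with methoxy in place of bromo, described above, gave a higher number, and a 3.3-fold higher number from compound 1 to compound 3 (0.52 log units; beyond the scatter) shows that hydrogen in place of propyl on the saturated chain carbon bound to the oxygen also gave a higher number. Both point the same way, so a modest rise beyond the scatter is expected for compound 4: a 2.4-fold higher number from compound 2 to compound 4 (0.39 log units; beyond the scatter). Compound 4 is therefore estimated at 30000 nM, with a range from 12000 nM to 75000 nM.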

Compound 4, inhibition constant: 89100 nM
Compound 4: middle estimate off by 3.0-fold (0.47 log units), on the low side; the measured number lies above the stated range.
By their numbers in this assay, from the lowest: compounds 1 and 2 (each within the scatter of the next); then compound 3; then compound 4.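

With hydroxy on this aromatic carbon, the number rises well beyond what bromo gives (a 7.2-fold higher number from compound 2 to compound 4 (0.86 log units; beyond the scatter)), and compound 4 has the highest number of the four. Losing the group on the oxygen also raises the number, both for methyl (a 3.1-fold higher number from compound 3 to compound 4 (0.49 log units; beyond the scatter)) and, by a larger step, for butyl (a 10-fold higher number from compound 1 to compound 4 (1.01 log units; beyond the scatter)). Nothing measured here explains why the free hydroxy stands apart. Still open, from the compounds shown here alone, is how an amine or a carboxylic acid at this place would compare with hydroxy, and whether a chain longer than butoxy would lower the number further.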